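The compounds below may be only part of what the source reports. "The series", "measured", "known", "first", "only" and "open" are said of these compounds alone.

Measured compounds in this set:
compound 1 `CO[C@H]1CCN2O[C@]34C=C[C@H](O)C[C@]3(OC(=O)C4)[C@@H]2C1` — > 10000 nM
compound 2 `CO[C@H]1CCN2O[C@H]3C=CC[C@@]4(OC(=O)C=C34)[C@@H]2C1` — > 10000 nM
compound 3 `O=C1C=C2C=C[C@H](O)C[C@]2(c2ccccn2)O1` — > 10000 nM

In an ADME assay on A549 cells (Homo sapiens) for cytotoxicity, read by sulforhodamine B assay, with a stated time of 48 h (a lower number here means a stronger inhibitor, a higher number a weaker inhibitor), compound 1 gives only a limit of the assay, > 10000 nM. Compound 2 likewise gives only a limit in this assay, > 10000 nM. Compound 3 also gives only a limit in this assay, > 10000 nM. Compound 3 therefore stands nowhere above or below its neighbours: every value shown sits at the same limit, (the limit of > 10000 nM in this assay, at which 3 of the 3 values shown sit), and no ordering among the three is possible.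

Compound 4 `O=C1C=C2C=CCC[C@]2(c2ccccn2)O1` has not been measured. It differs from compound 3 by hydrogen in place of hydroxy on a saturated ring carbon.

Going by the values given here, no step between measured compounds is available for this series, and the change is small. Given that all values shown rest at the limit (the limit of > 10000 nM in this assay, at which 3 of the 3 values shown sit), the step in this assay is expected to be none beyond the scatter, and compound 4 is expected to be reported as a limit again rather than a number. The expected step is a step that the limit leaves unreadable from compound 3 to compound 4. Compound 4 is estimated at 20000 nM, with a range from 6000 nM to 80000 nM.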

Compound 4, half-maximal inhibitory concentration: > 10000 nM
Compound 4 gave a limit, no number; the forecaster's own chance of this, stated with the estimate: 85%; the middle value is on the limit's open side.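

Going by these compounds alone, compound 3 and compound 4 both give only limits in this assay, and no step between them can be read: the limit of > 10000 nM in this assay, at which 4 of the 4 values shown sit.

The compounds shown leave open whether hydrogen in place of hydroxy on a saturated ring carbon changes the read-out at all, and what number any of these compounds would give.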